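The source may hold more compounds than are shown below. What is called first, only, known or untested is meant among the compounds shown, and "the series" means these compounds.

Three compounds from one series have been run through a functional assay on SW1573 cells (Homo sapiens) for inhibition, read by sulforhodamine B assay, with a stated time of 48 h; a higher number here means a weaker inhibitor of growth, a lower number a stronger inhibitor of growth. Compound 1 `COC(=O)[C@@]1(C)CC[C@@H]2C3=C1CC[C@@H](C)[C@]3(C)C[C@@H]1c3cc(Br)ccc3N[C@H]21` gives 45000 nM in this assay. Compound 2 `COC(=O)[C@@]1(C)CC[C@@H]2C3=C1CC[C@@H](C)[C@]3(C)C[C@@H]1c3cc(Cl)ccc3N[C@H]21` gives 38000 nM in this assay. Among the measured compounds shown here, the only change between these two is chloro in place of bromo on an aromatic carbon, and the step it made was a 1.2-fold lower number from compound 1 to compound 2 (0.07 log units; within the scatter). Compound 3 `COC(=O)[C@@]1(C)CC[C@@H]2C3=C1CC[C@@H](C)[C@]3(C)Cc1c2[nH]c2c(Br)cccc12` rests on a different core; the difference between its core and that of compound 1 is not broken down here. In this assay compound 3 gives 26000 nM, and its distance to compound 2 as well as to compound 1 lies within the scatter, so no order among the three can be drawn.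

Compound 4 `COC(=O)[C@@]1(C)CC[C@@H]2C3=C1CC[C@@H](C)[C@]3(C)Cc1c2[nH]c2c(Cl)cccc12` has not yet been measured. It differs from compound 3 by chloro in place of bromo on an aromatic carbon. For the measured compounds named here, this is the same kind of change as the one from compound 1 to compound 2, but not the same change: in compound 1 the bromo stands meta to a fused ring and para to a fused ring, whereas in compound 3 it stands ortho to a fused ring and meta to a fused ring. The expectation for compound 4 is a step of a 1.1-fold lower number from compound 3 to compound 4 (0.05 log units; within the scatter), resting on the earlier step of a 1.2-fold lower number from compound 1 to compound 2 (0.07 log units; within the scatter), which stayed within the scatter. The estimate for compound 4 in this assay is therefore 23000 nM, with a likely range from 12000 nM to 45000 nM.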

Compound 4, concentration for 50% growth inhibition: 17000 nM
Compound 4: the middle estimate sits 1.4-fold (0.13 log units) above what was measured; low and high end bracket the measured number.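

On the second core, putting chloro in place of bromo on an aromatic carbon gave in this assay a 1.5-fold lower number from compound 3 to compound 4 (0.18 log units; within the scatter), so the step can be read, but it does not separate the two halogens. Set beside the earlier step, the same change behaves alike on both cores, with no difference that can be told from the usual spread of such measurements: the same change on two cores in this assay, a 1.2-fold lower number (0.07 log units; within the scatter) from compound 1 to compound 2 and a 1.5-fold lower number (0.18 log units; within the scatter) from compound 3 to compound 4, 1.3-fold (0.11 log units) apart, within the scatter of two such steps This shows only that, in these two pairs, the exchange left the growth-inhibition reading within the scatter on either core; it does not show that chloro and bromo are interchangeable across the series, and since the halogen stands at a different place on each core, the effect of core and the effect of place cannot be told apart.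

All four compounds shown carry a single bromo or chloro on the aromatic ring and keep the methyl ester, so the halogen pairs say nothing about other groups on that carbon, such as an amine or a methoxy group. From the compounds shown here alone, whether a carboxylic acid or an amide in place of the methyl ester would move the reading beyond the scatter also remains open.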